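Sulfonamide nitrogen substituent swap in the thiourea series

The source may report more compounds than this note shows. Statements on the series, on what has been measured and on what is new or still open speak of the compounds shown alone.

Compound 3 `Cc1noc(NS(=O)(=O)c2ccc(N/C(S)=N\c3ccnc4cc(C(F)(F)F)ccc34)cc2)c1C` gives 34000 nM in a functional assay on AS49-RAW cells (Homo sapiens) for antiproliferative activity, read by sulforhodamine B assay, with a stated time of 48 h; a lower number here means a stronger inhibitor, a higher number a weaker inhibitor. Among the three measured compounds this is the second highest of 3 numbers: compound 2 `CC(=O)NS(=O)(=O)c1ccc(N/C(S)=N\c2ccnc3cc(C(F)(F)F)ccc23)cc1` gives 37600 nM in this assay, and compound 1 `Nc1ccc(S(=O)(=O)Nc2ccnc3cc(C(F)(F)F)ccc23)cc1` gives 29200 nM; both of these values lie within the scatter of the value of compound 3, so no ordering among the three is supported.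

Among the compounds with values here, the only measured step that touches the sulfonamide nitrogen is a 1.1-fold lower number from compound 2 to compound 3 (0.04 log units; within the scatter), where acetyl was exchanged for a five-membered aromatic ring and the number did not move beyond the scatter. Compound 4 `Cc1ccnc(NS(=O)(=O)c2ccc(N/C(S)=N\c3ccnc4cc(C(F)(F)F)ccc34)cc2)n1` differs from compound 3 at the same position: 4-methylpyrimidin-2-yl in place of 3,4-dimethyl-1,2-oxazol-5-yl on a sulfonamide nitrogen. One heteroaromatic ring of two hetero atoms and no donors replaces another of the same size and donor and acceptor count, on the nitrogen next to the sulfonyl sulfur. Within the data shown here, with the single relevant precedent showing no movement, the expected step is no change at the digits printed from compound 3 to compound 4 (within the scatter), within the scatter. The estimate for compound 4 is 34000 nM, with a range from 15000 nM to 80000 nM.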

Compound 4, half-maximal inhibitory concentration: 31000 nM
The estimate for compound 4 lay 1.1-fold (0.04 log units) above the measured number; the range from low to high includes it.
By their numbers in this assay, from the lowest: compounds 1, 4, 3 and 2 (each within the scatter of the next).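

In this assay, the exchange of a five-membered aromatic ring for a six-membered one on the sulfonamide nitrogen gives a 1.1-fold lower number from compound 3 to compound 4 (0.04 log units; within the scatter), so this change of ring size and ring hetero atoms leaves the number inside the scatter. The comparison of the non-ring acetyl with 4-methylpyrimidin-2-yl at the same place gives a 1.2-fold lower number from compound 2 to compound 4 (0.08 log units; within the scatter), and acetyl, 3,4-dimethyl-1,2-oxazol-5-yl and 4-methylpyrimidin-2-yl now all lie within the scatter of one another. Nothing available here bears on the reason for this flat response.

As far as these compounds go, whether a carboxylic acid, a primary amine or a longer alkyl chain on the sulfonamide nitrogen would move the number beyond the scatter remains open. Also open, from the compounds shown here alone, is whether any substituent at this place can separate compounds at all.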